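Cutting the Benzyl Group Down to Methyl

The source may report more compounds than this note shows. Statements on the series, on what has been measured and on what is new or still open speak of the compounds shown alone.

In a functional assay on Bel7402/5-FU cells (Homo sapiens) for antiproliferative activity, read by MTT assay, with a stated time of 72 h (a lower number here means a stronger inhibitor, a higher number a weaker inhibitor), compound 1 `C=C1C(=O)O[C@H]2[C@H]1CC/C(COC(=O)Cn1cc(F)c(=O)[nH]c1=O)=C\CC[C@@]1(C)O[C@@H]21` gives > 20000 nM which is a limit of the assay and not a number. In this assay compound 2 `C=C1C(=O)O[C@H]2[C@H]1CC/C(COC(=O)Cn1cc(F)c(=O)n(Cc3ccc(C(F)(F)F)cc3)c1=O)=C\CC[C@@]1(C)O[C@@H]21` gives 2250 nM and compound 3 `C=C1C(=O)O[C@H]2[C@H]1CC/C(COC(=O)Cn1cc(F)c(=O)n(Cc3ccc(F)c(F)c3)c1=O)=C\CC[C@@]1(C)O[C@@H]21` gives 4480 nM so compound 3 stands level with compound 2 (a 2.0-fold higher number from compound 2 to compound 3 (0.30 log units; within the scatter)). Compound 4 `C=C1C(=O)O[C@H]2[C@H]1CC/C(COC(=O)Cn1cc(F)c(=O)n(C)c1=O)=C\CC[C@@]1(C)O[C@@H]21` loses the ring (hydrogen in place of 3,4-difluorophenyl on a saturated chain carbon bound to an aromatic nitrogen): hydrogen in place of 3,4-difluorophenyl on a saturated chain carbon bound to an aromatic nitrogen, so 3,4-difluorobenzyl becomes methyl. Among the compounds with values here, two steps bear on this, both adding a benzyl group (an at least 8.8-fold lower number from compound 1 to compound 2 (0.94 log units; beyond the scatter); an at least 4.4-fold lower number from compound 1 to compound 3 (0.64 log units; beyond the scatter)). Methyl should keep only part of that gain. A weaker result is expected, a 2.2-fold higher number from compound 3 to compound 4 (0.35 log units; beyond the scatter) in this assay by this estimate. Compound 4 is estimated at 10000 nM with a range of 4000 nM to 25000 nM as the expected span.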

Compound 4, half-maximal inhibitory concentration: 11700 nM
Compound 4: middle estimate off by 1.2-fold (0.07 log units), on the low side, within the range that was stated.
By their numbers in this assay, from the lowest: compounds 2 and 3 (each within the scatter of the next); then compound 4. At a limit, above all of these: compound 1.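

Taking the ring away lowers activity at this aromatic nitrogen, so the gain seen with the benzyl groups needs more than replacing hydrogen: in this assay there is a 2.6-fold higher number from compound 3 to compound 4 (0.42 log units; beyond the scatter), and a 5.2-fold higher number from compound 2 to compound 4 (0.72 log units; beyond the scatter). Methyl on its own gives an at least 1.7-fold lower number from compound 1 to compound 4 (0.23 log units; that floor lies within the scatter), so any gain over hydrogen remains unproven. Compound 1 gives > 20000 nM, which is a limit and not a number.

Open, going by these compounds, is whether an ethyl group or a longer chain would recover part of the loss. Also open, on these data alone, is how a benzyl ring carrying an amine or a carboxylic acid would fare.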